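Notes on the carbonyl head group: compound 1 to compound 4

This account rests on a few compounds, and the source may have more. Where it says the series, first, only, none or still open, it means among the compounds named here.

Three compounds in this series carry numbers in an assay on a protein complex for inhibition of CDK8/Cyclin C (Homo sapiens), with a stated time of 1 h, tested at 10 uM (a lower number here means less inhibition, a higher number more inhibition at the concentration tested (going by the name of the read-out)), so far. Compound 1 `NC(=O)/C=C/c1ccncc1-c1ccc2ccccc2c1` stands highest of the three, giving 102%. Compound 3 `CNC(=O)/C=C/c1ccncc1-c1ccc2c(ccn2C)c1` gives 99% in this assay, a number that lies within the scatter of compound 1 and so cannot be ordered against it. Compound 2 `O=C(/C=C/c1ccncc1-c1ccc2cccnc2c1)N1CCOCC1` gives 33% in this assay, a number that falls beyond the scatter below compound 1. Among the measured compounds shown here, no two of the three differ in only one place, so no single step between measured compounds is available; compound 2 differs from compound 1 both in its core and in the group on the carbonyl carbon, and its gap to compound 1 cannot be assigned to either change.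

Compound 4 `CN(C)C(=O)/C=C/c1ccncc1-c1ccc2ccccc2c1` has not been measured. Its difference from compound 1 is dimethylamino in place of amino on a carbonyl carbon. For the measured compounds named here, the nearest precedent for a carbonyl carbon bearing no hydrogen-bond donor is compound 2, whose 33% marks the lower end of what is expected, while compound 1 with 102% marks the upper end. The step from compound 1 to compound 4 is expected to be a fall, a number 42 percentage points lower from compound 1 to compound 4 (beyond the scatter), beyond the scatter but uncertain in size. Compound 4 is estimated at 60% with a range from 25% to 95% in this assay.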

Compound 4, a percentage reported as inhibition, at one concentration (the size of the read-out at that concentration, not a potency): 100%
The estimate for compound 4 lay 40 percentage points below the measured number; the measured number lies above the stated range.
By their numbers in this assay, from the lowest: compound 2; then compounds 3, 4 and 1 (each within the scatter of the next).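

Among the compounds shown here, the single step now available in this assay reads a number 2 percentage points lower from compound 1 to compound 4 (within the scatter), with dimethylamino in place of amino on a carbonyl carbon. On the core of compound 1, the count on this group can therefore go from 1 hydrogen-bond donor to 0 hydrogen-bond donors and from 1 heavy atom to 3 heavy atoms without a change beyond the scatter, so a donor on this group is not needed for the number seen at this one concentration, although such a read-out is not a potency and any difference in potency between compound 1 and compound 4 would not be shown by it. No measurement is available that accounts for the size of this step.

Compound 2 still differs from compound 1 in two places, so its gap cannot be divided between the core and the morpholine on the carbonyl carbon. Going by these compounds, whether a carboxylic acid, a methyl ester or a longer chain on the amide nitrogen would hold the number in this assay on the core of compound 1 remains open.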